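Brominated triaryl cyclopentenone series: cytotoxicity in lung carcinoma cells

The compounds below may be only part of what the source reports. "The series", "measured", "known", "first", "only" and "open" are said of these compounds alone.

Measured compounds, with their results in a functional assay on A549 cells (Homo sapiens) for cytotoxicity, read by sulforhodamine B assay, with a stated time of 72 h; a higher number here means a weaker inhibitor, a lower number a stronger inhibitor:
compound 1 `COC(=O)C1=C(c2cc(Br)c(O)c(Br)c2)C(=O)[C@](OC)(c2ccc(O)c(Br)c2)O[C@]1(OC)c1cc(Br)c(O)c(Br)c1`, compound 1 gives > 10000 nM
compound 2 `O=C1C=C(c2cc(Br)c(O)c(Br)c2)C(=O)C1(c1cc(Br)c(O)c(Br)c1)c1cc(Br)c(O)c(Br)c1`, compound 2 gives > 10000 nM
compound 3 `O=C(O)C1=C(c2ccc(O)c(Br)c2)C(=O)C(c2cc(Br)c(O)c(Br)c2)(c2cc(Br)c(O)c(Br)c2)C1=O`, compound 3 gives > 10000 nM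

Every one of these three values is a limit of this assay and not a number. For compound 1 the value is such a limit. For compound 2 the value is such a limit as well. For compound 3 the value is likewise a limit. Compound 2 therefore has no measured position relative to the other two; all that can be said is the limit of > 10000 nM in this assay, at which 3 of the 3 values shown sit. Among the compounds with values here, no pair among the measured compounds differs in a single place, so no measured step is available.

Within the data shown here, compound 4 `COC(=O)C1=C(c2cc(Br)c(O)c(Br)c2)C(=O)C(c2cc(Br)c(O)c(Br)c2)(c2cc(Br)c(O)c(Br)c2)C1=O` is the one compound of the four still to be measured in this assay. Compared with compound 2 the difference is methoxycarbonyl in place of hydrogen on a double-bonded ring carbon.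

Among the measured compounds shown here, with no measured step to lean on, and with every measured value at the limit, no shift beyond the scatter is expected in either direction: the step from compound 2 to compound 4 is estimated as a step that the limit leaves unreadable from compound 2 to compound 4. Compound 4 is estimated at 15000 nM, within a range from 5000 nM to 50000 nM, with a limit rather than a number the most likely report.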

Compound 4, half-maximal inhibitory concentration: > 10000 nM
Compound 4 gave a limit, no number; the forecaster's own chance of this, stated with the estimate: 85%; the middle value lies beyond the limit too.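

The result for compound 4 is a limit and not a number, so no step can be read between compound 2 and compound 4 in this assay. The compounds shown leave open whether any change on the shared core shifts cytotoxicity in this series, with every value resting at one limit: the limit of > 10000 nM in this assay, at which 4 of the 4 values shown sit.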